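A Nitro-for-Cyano Swap Tested on Two Cores

The compounds below may be only part of what the source reports. "The series", "measured", "known", "first", "only" and "open" are said of these compounds alone.

Compound 1 `CC(O)(COc1ccc(S(F)(F)(F)(F)F)cc1)C(=O)Nc1ccc(C#N)cc1C(F)(F)F` and compound 2 `CC(O)(COc1ccc(S(F)(F)(F)(F)F)cc1)C(=O)Nc1ccc([N+](=O)[O-])cc1C(F)(F)F` share one core, while compound 3 `CC(O)(CS(=O)(=O)c1cccc(S(F)(F)(F)(F)F)c1)C(=O)Nc1ccc(C#N)cc1C(F)(F)F` and compound 4 `CC(O)(CS(=O)(=O)c1cccc(S(F)(F)(F)(F)F)c1)C(=O)Nc1ccc([N+](=O)[O-])cc1C(F)(F)F` share another; the difference between the two cores is not broken down here. In a functional assay on VCaP cells (Homo sapiens) for antiproliferative activity, read by propidium iodide staining, with a stated time of 96 h (a higher number here means a weaker inhibitor, a lower number a stronger inhibitor), compound 1 gives 25500 nM, and compound 2 gives 26100 nM. The change between them, (nitro in place of cyano on an aromatic carbon), made a step of a 1.0-fold higher number from compound 1 to compound 2 (0.01 log units; within the scatter). In this assay compound 3 gives 20800 nM. That number and those of compound 1 and compound 2 lie within the scatter of one another, so no order among the three can be claimed. Compound 4 differs from compound 3 by nitro in place of cyano on an aromatic carbon, the same change as from compound 1 to compound 2, at a place described in the same words. For the measured compounds named here, the step expected is a 1.0-fold higher number from compound 3 to compound 4 (0.01 log units; within the scatter), since the only precedent is a 1.0-fold higher number from compound 1 to compound 2 (0.01 log units; within the scatter). That expectation rests on a single pair and nothing more. Compound 4 is therefore estimated at 21500 nM in this assay, with a likely range from 10500 nM to 44000 nM.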

Compound 4, half-maximal inhibitory concentration: 100000 nM
The estimate for compound 4 lay 4.7-fold (0.67 log units) below the measured number; the whole stated range lies below it.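

In this assay, nitro in place of cyano on an aromatic carbon gave a step of a 4.8-fold higher number from compound 3 to compound 4 (0.68 log units; beyond the scatter), whereas on the core of compound 1 the same change left the values within the scatter. The change therefore did not carry over from one core to the other with the same size of step: the same change on two cores in this assay, a 1.0-fold higher number (0.01 log units; within the scatter) from compound 1 to compound 2 and a 4.8-fold higher number (0.68 log units; beyond the scatter) from compound 3 to compound 4, 4.7-fold (0.67 log units) apart, beyond the scatter of two such steps These two pairs, read in a single assay, do not tell which feature of the two cores separates the steps, nor how the change would behave on any further core.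

The compounds shown leave open whether another group on the same aromatic carbon, such as an amine or a carboxylic acid, would also give steps that differ between the two cores. They also leave open whether the two steps would still differ if a chlorine atom stood in place of the trifluoromethyl group on that ring.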